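The source may report more compounds than this note shows. Statements on the series, on what has been measured and on what is new or still open speak of the compounds shown alone.

Of the compounds shown here, three have been measured in a functional assay on HCC827 cells (Homo sapiens) for antiproliferative activity, read by MTT assay, with a stated time of 72 h; on this read-out higher numbers stand for weaker inhibition and lower numbers for stronger inhibition. Compound 1 `CN1CCN(c2ccc(Nc3ncc4nc(Nc5ccc(F)cc5)n([C@H]5CCCNC5)c4n3)cc2)CC1` gives 38 nM, compound 2 `CN1CCN(c2ccc(Nc3ncc4nc(Nc5ccc(F)cc5)n([C@H]5CCN(C(=O)OC(C)(C)C)C5)c4n3)cc2)CC1` gives 580 nM and compound 3 `CN1CCN(c2ccc(Nc3ncc4nc(Nc5ccc(F)cc5)n(CCNS(=O)(=O)C5CC5)c4n3)cc2)CC1` gives 50 nM, so compound 3 sits with compound 1, within the scatter, and far below compound 2. All three differ only on the same aromatic nitrogen: a 15-fold higher number from compound 1 to compound 2 (1.18 log units; beyond the scatter), a 1.3-fold higher number from compound 1 to compound 3 (0.12 log units; within the scatter) and a 12-fold lower number from compound 2 to compound 3 (1.06 log units; beyond the scatter). Compound 4 `CC(=O)Nc1cccc(-n2c(Nc3ccc(F)cc3)nc3cnc(Nc4ccc(N5CCN(C)CC5)cc4)nc32)c1` carries 3-acetamidophenyl in place of 2-((cyclopropylsulfonyl)amino)ethyl on an aromatic nitrogen. Going by the values given here, no measured step exchanges a chain for an aryl group at that nitrogen, so the two large steps and the one within the scatter show only that this position can move the number strongly. For compound 4 a modestly higher number is expected, a step of a 2.4-fold higher number from compound 3 to compound 4 (0.38 log units; beyond the scatter) in this assay. The estimate for compound 4 is 120 nM, within 30 nM to 500 nM.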

Compound 4, half-maximal inhibitory concentration: 10 nM
Beside the measured number, compound 4's estimate is 12-fold (1.08 log units) above it, and the stated range ends above it.
By their numbers in this assay, from the lowest: compound 4; then compounds 1 and 3 (each within the scatter of the next); then compound 2.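

In this assay 3-acetamidophenyl on this aromatic nitrogen gives a 5.0-fold lower number from compound 3 to compound 4 (0.70 log units; beyond the scatter) and a 3.8-fold lower number from compound 1 to compound 4 (0.58 log units; beyond the scatter) and also a 58-fold lower number from compound 2 to compound 4 (1.76 log units; beyond the scatter) in the set. All three steps lie beyond the scatter, so a six-membered aromatic ring of carbon only is accepted at this place and compound 4 has the lowest number of the four. Nothing measured here accounts for these steps. Open, going by these compounds, is whether the phenyl ring or the acetamido group carries the gain, and how plain phenyl, 3-aminophenyl or 3-carboxyphenyl would read at this nitrogen.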